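Capping an oxygen with a (4-methylphenyl)sulfonyl group

A few compounds are considered here, and "the series" means these few. Any claim that something is new, unique, unknown or untested is made for them only; others in the source may bear on it.

Of the compounds shown here, three built on one shared core have been tested so far for how much of each cells can tolerate. Compound 1 `O[C@@H]1CO[C@H]2[C@@H]1OCc1nc3cc(Br)cc(Cl)c3n12` gives > 800000 nM in an ADME assay on HEp-2 cells (Homo sapiens) for cytotoxicity, read by MTT assay, with a stated time of 60 h (a higher number here means that more compound is tolerated, a lower number that less compound is tolerated), as its result, and this is a limit of the assay and not a number. Compound 2 `O[C@@H]1CO[C@H]2[C@@H]1OCc1nc3cc(Br)c(Br)cc3n12` gives 181000 nM in this assay and compound 3 `Cc1c(Br)cc2nc3n(c2c1Br)[C@H]1OC[C@@H](O)[C@H]1OC3` gives 250000 nM there, two numbers that lie within the usual scatter of each other. Compound 3 therefore stands level with compound 2 on the numbers available.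

Compound 4 `Cc1ccc(S(=O)(=O)O[C@@H]2CO[C@H]3[C@@H]2OCc2nc4cc(Br)c(C)c(Br)c4n23)cc1` keeps the core of compound 3 and differs in one place, with (4-methylphenyl)sulfonyl in place of hydrogen on an oxygen on a saturated carbon as the counted change: (4-methylphenyl)sulfonyl in place of hydrogen on an oxygen on a saturated carbon. Among the measured compounds shown here, no measured compound carries this group, and no measured pair differs in one place only, so the data give no direct guide to this step. A cautious expectation is a modest move towards a lower number, with the estimated step of a 2.5-fold lower number from compound 3 to compound 4 (0.40 log units; beyond the scatter) only slightly beyond the scatter. For compound 4 the estimated half-maximal cytotoxic concentration is 100000 nM in this assay with an expected range from 25000 nM to 400000 nM for the measurement to come.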

Compound 4, half-maximal cytotoxic concentration: 88600 nM
For compound 4 the middle estimate is 1.1-fold (0.05 log units) above the measured one; the range from low to high includes it.
By their numbers in this assay, from the lowest: compound 4; then compounds 2 and 3 (each within the scatter of the next). At a limit, above all of these: compound 1.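

Among the compounds shown here, compound 4 gives the only measured step at this oxygen in this assay: a 2.8-fold lower number from compound 3 to compound 4 (0.45 log units; beyond the scatter). Replacing the hydrogen on an oxygen on a saturated carbon with (4-methylphenyl)sulfonyl, a group of 10 heavy atoms with one six-membered aromatic ring of carbon only, therefore moves the number by a modest amount, and this single pair shows that such a large group can sit at this place while compound 4 still gives a measured number of 88600 nM rather than a limit. Nothing in the data shown accounts for why the number moves in this direction.

One step cannot show which part of the entering group matters, and a smaller acetyl group, a methyl ether or an amine at the same place would help to separate the effect of the aromatic ring from that of the sulfonyl part. From the compounds shown here alone, it also remains open whether the same (4-methylphenyl)sulfonyl group on the oxygen of compound 2 would give a step of similar size.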